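The source may report more compounds than this note shows. Statements on the series, on what has been measured and on what is new or still open speak of the compounds shown alone.

Of the compounds shown here, three that share one core have been tested in an ADME assay on Vero cells (Chlorocebus sabaeus) for cytotoxicity, read by MTT assay, with a stated time of 48 h; on this read-out higher numbers stand for weaker inhibition and lower numbers for stronger inhibition. Among the measured compounds shown here, compound 2 `CS(=O)(=O)NC1CCC(CN2CCN(c3cc(=O)c4cc(C(F)(F)F)cc([N+](=O)[O-])c4s3)CC2)CC1` gives 48.5 ug/mL, the only actual number so far. Compound 1 `O=C(OC1CCC(CN2CCN(c3cc(=O)c4cc(C(F)(F)F)cc([N+](=O)[O-])c4s3)CC2)CC1)c1ccccc1` gives > 64 ug/mL, which is a limit of the assay and not a number. Compound 3 `O=c1cc(N2CCN(CC3CCC(OS(=O)(=O)c4ccc5ccccc5c4)CC3)CC2)sc2c([N+](=O)[O-])cc(C(F)(F)F)cc12` gives > 64 ug/mL, which is also a limit. The picture therefore rests largely on (the limit of > 64 ug/mL in this assay, at which 2 of the 3 values shown sit).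

Compound 4 `O=C(OC1CCC(CN2CCN(c3cc(=O)c4cc(C(F)(F)F)cc([N+](=O)[O-])c4s3)CC2)CC1)c1cccc(F)c1` has not yet been measured. Reaching it from compound 2 means (((3-fluorophenyl)carbonyl)oxy in place of methanesulfonamido on a saturated ring carbon), with ((3-fluorophenyl)carbonyl)oxy in place of methanesulfonamido on a saturated ring carbon. For the measured compounds named here, the one measured step that bears on this, an at least 1.3-fold lower number from compound 1 to compound 2 (0.12 log units; that floor lies within the scatter), has methanesulfonamido in place of benzoyloxy on a saturated ring carbon, so the reverse kind of change is expected to raise the number in this assay, though perhaps not beyond the scatter. The expected size is a 1.5-fold higher number from compound 2 to compound 4 (0.17 log units; within the scatter). For compound 4 the estimate is 72 ug/mL, with an expected range of 45 ug/mL to 130 ug/mL, and the assay may well report only a limit.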

Compound 4, half-maximal inhibitory concentration: > 64 ug/mL
Compound 4 gave a limit, no number; the forecaster's own chance of this, stated with the estimate: 70%; the middle value lies beyond the limit too.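

In this assay, ((3-fluorophenyl)carbonyl)oxy in place of methanesulfonamido on the saturated ring carbon gives an at least 1.3-fold higher number from compound 2 to compound 4 (0.12 log units; that floor lies within the scatter), so this second swap away from methanesulfonamido also shows no change beyond the scatter. As far as these compounds go, for compound 4, > 64 ug/mL is a limit of the assay and not a number, so the true size of this step stays unknown. The steps between compound 1 and compound 4 cannot be read, so fluoro in place of hydrogen on the aromatic carbon shows nothing here, since the picture now rests even more on a single boundary: the limit of > 64 ug/mL in this assay, at which 3 of the 4 values shown sit.

Only compound 2 has an actual number, so it remains unclear how much the group on this saturated ring carbon matters in this assay. From the compounds shown here alone, whether an amine or a carboxylic acid on that same carbon would give a real number, and so a step that can be read, stays open.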